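Aryl swap on the saturated ring carbon

This account rests on a few compounds, and the source may have more. Where it says the series, first, only, none or still open, it means among the compounds named here.

Measured so far:
compound 1 `CC(=O)N1N=C(c2ccccc2O)CC1c1cccc(C)c1` gives 5500 nM
compound 2 `CC(=O)N1N=C(c2ccccc2)CC1c1ccc(Cl)cc1` gives 6000 nM

In an assay on mitochondria for inhibition of Monoamine oxidase (Bos taurus) (on this read-out higher numbers stand for weaker inhibition and lower numbers for stronger inhibition), compound 2 has the highest of the two numbers; its nearest neighbour, compound 1, lies within the scatter, so the two show no ordering. Compound 3 `CC(=O)N1N=C(c2ccccc2)CC1c1cccc(C)c1` is not yet measured. It differs from compound 2 by 3-methylphenyl in place of 4-chlorophenyl on a saturated ring carbon. For the measured compounds named here, no measured pair shows this change alone, so only a small step, or none beyond the scatter, is expected in this assay. Compound 3 is estimated at 5000 nM, with a range from 2000 nM to 15000 nM. That estimate means a step of a 1.2-fold lower number from compound 2 to compound 3 (0.08 log units; within the scatter).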

Compound 3, inhibition constant: 200000 nM
Compound 3: middle estimate off by 40-fold (1.60 log units), on the low side, outside the stated range (above it).
By their numbers in this assay, from the lowest: compounds 1 and 2 (each within the scatter of the next); then compound 3.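

In this assay the aryl group on the saturated ring carbon is not a neutral swap: 3-methylphenyl in place of 4-chlorophenyl gives a large change (a 33-fold higher number from compound 2 to compound 3 (1.52 log units; beyond the scatter)). With 3-methylphenyl kept, hydrogen in place of hydroxy on an aromatic carbon gives a similarly large change (a 36-fold higher number from compound 1 to compound 3 (1.56 log units; beyond the scatter)), so the closeness of compound 1 and compound 2 hid two separate large effects. No evidence on the origin of either step is available. Still open, going by these compounds, is whether hydroxy has the same effect alongside 4-chlorophenyl, and whether methoxy or an amine can replace it.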